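Acetyl to Propanoyl on Two Sulfonyl-Bearing Cores

A few compounds are considered here, and "the series" means these few. Any claim that something is new, unique, unknown or untested is made for them only; others in the source may bear on it.

Compound 1 `CCCS(=O)(=O)N1CCCN(C(C)=O)CC1` gives > 10 mg/kg in a functional assay on the whole organism with Mus musculus as the target (on this read-out lower numbers stand for an effect already at smaller amounts and higher numbers for an effect only at larger amounts of compound), which is a limit rather than a number.
Compound 2 `CCCS(=O)(=O)N1CCCN(C(=O)CC)CC1` gives > 10 mg/kg in this assay, again a limit.
Compound 3 `CC(=O)N1CCCN(S(=O)(=O)c2ccc(F)cc2)C1` gives 1 mg/kg in this assay.

Compound 1 and compound 2 share a core and differ by methyl in place of hydrogen on a saturated chain carbon bound to a carbonyl carbon. The step they made is a step that the two limits leave unreadable from compound 1 to compound 2; its size cannot be read because of the limit of > 10 mg/kg in this assay, at which 2 of the 3 values shown sit. Compound 3 stands on a different core, and the difference between the two cores is not broken down here.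

Compound 4 `CCC(=O)N1CCCN(S(=O)(=O)c2ccc(F)cc2)C1` has not yet been measured in this assay. It differs from compound 3 by methyl in place of hydrogen on a saturated chain carbon bound to a carbonyl carbon, the same change as that from compound 1 to compound 2, made on the other core. Since the earlier step left no readable size, the expectation for compound 4 rests on compound 3 and its value 1 mg/kg, together with the smallness of the change. Compound 4 is expected to sit close to compound 3, at an estimated step of no change at the digits printed from compound 3 to compound 4 (within the scatter). Compound 4 is therefore estimated at 1 mg/kg, between 0.3 mg/kg and 3 mg/kg.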

Compound 4, minimum effective dose: 1 mg/kg
Beside the measured number, compound 4's estimate shows no gap at the digits printed; the measured number falls inside the stated range.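

In this assay, putting methyl in place of hydrogen on a saturated chain carbon bound to a carbonyl carbon, which turns acetyl into propanoyl, gives no change at the digits printed from compound 3 to compound 4 (within the scatter). On the core of compound 3, then, this small change leaves the minimum effective dose where it was. The same change on the core of compound 1 cannot be set beside this result, because neither end of that step is a number, so the step cannot be read: the limit of > 10 mg/kg in this assay, at which 2 of the 4 values shown sit. This leaves a single readable step on a single core, which does not show that the change behaves alike on both cores.

From the compounds shown here alone, it remains open whether a longer chain, such as butanoyl in place of propanoyl, or an amine or a carboxylic acid placed on that same chain carbon, would leave the read-out unchanged on the core of compound 3. Also open, going by these compounds, is how much of the difference in read-out belongs to the cores themselves.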